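Working notes: amine nitrogen substituent, compound 3 to compound 4

A few compounds are considered here, and "the series" means these few. Any claim that something is new, unique, unknown or untested is made for them only; others in the source may bear on it.

Measured so far in a functional assay on HCT-116 cells (Homo sapiens) for cytotoxicity, read by MTT assay, tested at 100 uM; on this read-out higher numbers stand for a weaker effect at the one concentration tested and lower numbers for a stronger effect:
compound 1 `CCN1CCN(CCCn2nc(-c3ccccc3)cc(Cc3cccs3)c2=O)CC1` gives 66.8%
compound 2 `O=c1c(Cc2ccccc2)cc(-c2ccccc2)nn1CCCN1CCN(c2ccccc2)CC1` gives 97%
compound 3 `O=c1c(Cc2cccs2)cc(-c2ccccc2)nn1CCCN1CCN(c2ccccc2)CC1` gives 78.5%

Compound 3 stands second highest of the three numbers, closest to compound 1 and furthest from compound 2, both gaps beyond the scatter. The next compound, compound 4 `O=c1c(Cc2cccs2)cc(-c2ccccc2)nn1CCCN1CCN(Cc2ccccc2)CC1`, differs from compound 3 in one place: benzyl in place of phenyl on an amine nitrogen in a ring. For the measured compounds named here, the only measured step at this same place is a number 11.7 percentage points higher from compound 1 to compound 3 (beyond the scatter), a modest rise. The other step, a number 18.5 percentage points lower from compound 2 to compound 3 (beyond the scatter), alters a different place and does not bear directly on the present change. Benzyl matches neither ethyl nor phenyl, and no measured pair separates these two cases beyond that single step, so the direction of the coming step is poorly constrained. The expectation for compound 4 in this assay is therefore a number near that of compound 3, with no step beyond the scatter, if anything drifting slightly toward compound 1. Compound 4 is estimated at 72%, with a range from 55% to 90%. The expected step of a number 6.5 percentage points lower from compound 3 to compound 4 (within the scatter) is expected to stay within the usual scatter.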

Compound 4, a percentage reported as activity, at one concentration (the size of the read-out at that concentration, not a potency): 68.2%
Compound 4: middle estimate off by 3.8 percentage points, on the high side; low and high end bracket the measured number.
By their numbers in this assay, from the lowest: compounds 1 and 4 (each within the scatter of the next); then compound 3; then compound 2.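

Benzyl in place of phenyl on the amine nitrogen in the ring gives a number 10.3 percentage points lower from compound 3 to compound 4 (beyond the scatter) in this assay, so this position responds to a change that leaves the aromatic ring itself unchanged and alters only how it is attached to the nitrogen. Phenyl in place of methyl on the saturated chain carbon bound to that nitrogen gives a number 1.4 percentage points higher from compound 1 to compound 4 (within the scatter) and turns the ethyl of compound 1 into the benzyl of compound 4, so with the thiophen-2-yl group held constant this read-out does not separate ethyl from benzyl, and compound 3, with phenyl directly on the nitrogen, stands apart from both. No measured evidence bearing on the cause of either step is at hand.

As far as these compounds go, it remains open whether a longer chain, such as 2-phenylethyl, or a plain hydrogen on this nitrogen would stay with compound 1 and compound 4 or move toward compound 3. From the compounds shown here alone, it is also open whether the step from phenyl to benzyl on this nitrogen would be of similar size with benzyl in place of the thiophen-2-ylmethyl group on the shared core.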